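This account rests on a few compounds, and the source may have more. Where it says the series, first, only, none or still open, it means among the compounds named here.

Of the compounds shown here, three have so far been measured in a functional assay on RAW264.7 cells (Mus musculus) for inhibition, read by Griess assay, with stated times of 2 h and 24 h; a higher number here means a weaker inhibitor, a lower number a stronger inhibitor. Compound 1 `CCn1cc(COc2cc(O)c3c(c2)O[C@H](c2ccc(OC)c(O)c2)C/C3=N\O)nn1` gives 3140 nM, compound 2 `CCCCn1cc(COc2cc(O)c3c(c2)O[C@H](c2ccc(OC)c(O)c2)C/C3=N\O)nn1` gives 8900 nM, and compound 3 `COc1ccc([C@@H]2CC(=O)c3c(O)cc(OCc4cn(Cc5cccc(C#N)c5)nn4)cc3O2)cc1O` gives 18000 nM. Compound 3 stands highest of the three, which here means it is the weakest inhibitor of the set; compound 2 is its nearest neighbour and compound 1 lies furthest from it. Compound 4 `CCn1cc(COc2cc(O)c3c(c2)O[C@H](c2ccc(OC)c(O)c2)CC3=O)nn1` has not yet been measured. It differs from compound 3 at one point: methyl in place of 3-cyanophenyl on a saturated chain carbon bound to an aromatic nitrogen. Going by the values given here, compound 3 and compound 4 share a core that is not the same as that of compounds 1 and 2, so no measured step matches this change exactly. Among the compounds with values here, the one step that bears on it concerns the chain on the aromatic nitrogen: from compound 1 to compound 2, ethyl replaces hydrogen two bonds along the chain from that nitrogen, and the number rises, a 2.8-fold higher number from compound 1 to compound 2 (0.45 log units; beyond the scatter). A longer group on that chain thus went with weaker inhibition, and the change from compound 3 to compound 4 removes a much larger group. The step from compound 3 to compound 4 in this assay is therefore expected to be a drop, a 3.0-fold lower number from compound 3 to compound 4 (0.48 log units; beyond the scatter). Compound 4 is estimated at 6000 nM, with a range from 2500 nM to 15000 nM.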

Compound 4, half-maximal inhibitory concentration: 15000 nM
Beside the measured number, compound 4's estimate is 2.5-fold (0.40 log units) below it; the range from low to high includes it.
By their numbers in this assay, from the lowest: compound 1; then compounds 2, 4 and 3 (each within the scatter of the next, the first and the last beyond it).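

Replacing 3-cyanophenyl with methyl on a saturated chain carbon bound to an aromatic nitrogen removes a whole aromatic ring and its nitrile, yet in this assay the result is only a small difference that cannot be told apart from assay noise (a 1.2-fold lower number from compound 3 to compound 4 (0.08 log units; within the scatter)). On the core shared by these two compounds, then, a large aromatic group and a small ethyl group on the aromatic nitrogen read alike, whereas the earlier chain change on the other core was larger than the scatter (a 2.8-fold higher number from compound 1 to compound 2 (0.45 log units; beyond the scatter)). Nothing available explains why the size of the group counts for so little in this pair.

The ring and the nitrile leave together in this change, so a plain benzyl group would be needed to show whether either of them matters alone. As far as these compounds go, it also remains open whether a different kind of group at this place, such as an amine or a carboxylic acid on the chain, would move the number away from the level these two compounds share.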